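This account rests on a few compounds, and the source may have more. Where it says the series, first, only, none or still open, it means among the compounds named here.

In a functional assay on Jurkat cells (Homo sapiens) for inhibition (on this read-out higher numbers stand for weaker inhibition and lower numbers for stronger inhibition), two compounds have been measured so far. Compound 1 `CCOC(=O)c1cnc(N(C(=O)c2ccccc2)N2C(=O)C=C(C)C2=O)nc1C(F)(F)F` gives 830 nM. Compound 2 `CCOC(=O)c1cnc(NN2C(=O)C=C(C)C2=O)nc1` gives 13000 nM, the higher of the two numbers and beyond the usual scatter from compound 1, so compound 2 stands as the weaker inhibitor of the pair. Compound 3 `CCOC(=O)c1cnc(NN2C(=O)C=C(C)C2=O)nc1-c1ccsc1` has not yet been measured in this assay. It differs from compound 2 in one place: thiophen-3-yl in place of hydrogen on an aromatic carbon. Going by the values given here, no step between measured compounds isolates this change, so its size cannot be read directly from the data. Because compound 1 gives 830 nM while carrying groups on the shared core where compound 2 carries hydrogen, a modest move toward stronger inhibition is expected for compound 3, though no change beyond the scatter remains possible. Compound 3 is estimated at 4000 nM, within 1000 nM to 15000 nM, an expected step of a 3.3-fold lower number from compound 2 to compound 3 (0.51 log units; beyond the scatter).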

Compound 3, half-maximal inhibitory concentration: 200 nM
Compound 3: the middle estimate sits 20-fold (1.30 log units) above what was measured, outside the stated range (below it).
By their numbers in this assay, from the lowest: compound 3; then compound 1; then compound 2.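

In this assay the replacement of hydrogen by thiophen-3-yl, on the aromatic carbon next to the ring nitrogen and ortho to the ethoxycarbonyl group, produces a 65-fold lower number from compound 2 to compound 3 (1.81 log units; beyond the scatter) in a single change. Going by these compounds alone, this is the first direct reading at this position, and it shows that this one substitution alone moves the number by a large step, something the earlier pair, which differs in more than one place, could not isolate. No measured evidence bears on why the step is this large.

Going by these compounds, whether this gain is particular to thiophen-3-yl or would also come with a phenyl ring, a methyl group or an amine on the same carbon remains open. Compound 1 carries trifluoromethyl there but also a benzoyl group on the linking nitrogen, so the contribution of trifluoromethyl alone cannot be read.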